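A few compounds are considered here, and "the series" means these few. Any claim that something is new, unique, unknown or untested is made for them only; others in the source may bear on it.

Three compounds share one core. Compound 1 `Cc1nc2c(OCc3ccccc3)cccn2c1CCC#N` gives 40% in a functional assay on the whole organism with Rattus norvegicus as the target, with a stated time of 4 h, at a dose of 40 mg/kg by the intraperitoneal route (a lower number here means less inhibition, a higher number more inhibition at the dose given (going by the name of the read-out)), compound 2 `Cc1nc2c(OCc3ccccc3)cccn2c1C[S+](C)[O-]` gives 0%, and compound 3 `Cc1nc2c(OCc3ccccc3)cccn2c1Cl` gives 93%. Compound 3 stands highest of the three: the step from compound 1 to compound 3 is a number 53 percentage points higher from compound 1 to compound 3 (beyond the scatter), and from compound 2 to compound 3 it is a number 93 percentage points higher from compound 2 to compound 3 (beyond the scatter). Compound 4 `Cc1nc2c(OCc3ccccc3)cccn2c1COC(=O)C(C)(C)C` differs from compound 3 by (((tert-butyl)carbonyl)oxy)methyl in place of chloro on an aromatic carbon. Both measured steps onto compound 3 show that a chain replacing chloro at this carbon goes with much lower inhibition, so a large fall is expected for compound 4, estimated as a number 58 percentage points lower from compound 3 to compound 4 (beyond the scatter). Compound 4 is therefore expected to give about 35%, within a range of 0% to 75%.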

Compound 4, a percentage reported as inhibition, in the whole organism at one dose (the size of the read-out at that dose, not a potency): 48%
Compound 4: the middle estimate sits 13 percentage points below what was measured, and the stated range covers the measured number.
By their numbers in this assay, from the lowest: compound 2; then compounds 1 and 4 (each within the scatter of the next); then compound 3.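

In this assay, (((tert-butyl)carbonyl)oxy)methyl also falls well short of chloro on this aromatic carbon (a number 45 percentage points lower from compound 3 to compound 4 (beyond the scatter)), so the fall now holds for three different chains. Those chains do not all behave alike: compound 4 clearly exceeds the sulfur-bearing compound 2 (a number 48 percentage points higher from compound 2 to compound 4 (beyond the scatter)), so a chain here does not always remove the inhibition. The ((tert-butyl)carbonyl)oxy and cyanomethyl ends cannot be told apart (a number 8 percentage points higher from compound 1 to compound 4 (within the scatter)).

On these data alone, whether an amine or a carboxylic acid on the saturated chain carbon, or bromo on the aromatic carbon, would come closer to chloro stays open. Nothing given here explains why these groups differ.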